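Removing the Chloro Group from Compound 1

The compounds below may be only part of what the source reports. "The series", "measured", "known", "first", "only" and "open" are said of these compounds alone.

Compound 1 `Cc1cc(C)nc(SCc2cc(=O)c3cc(Cl)ccc3o2)n1`: in a functional assay on MCF7 cells (Homo sapiens) for cytotoxicity, read by MTT assay, with a stated time of 72 h (a lower number here means a stronger inhibitor, a higher number a weaker inhibitor), compound 1 gives > 25000 nM, a limit of the assay.
Compound 2 `Cc1nnc(Sc2coc3ccccc3c2=O)s1`: compound 2 gives > 50000 nM, a limit of the assay.
Compound 3 `Cc1cc(O)cc2oc(=O)cc(CSc3nc4ccccc4[nH]3)c12`: compound 3 gives > 25000 nM, a limit of the assay.

Compound 1 stands at the limit of > 25000 nM in this assay, at which 2 of the 3 values shown sit, which compound 3 also reaches, while compound 2 sits at the limit of > 50000 nM in this assay, at which 1 of the 3 values shown sits. For the measured compounds named here, none of the three gives a number, so no step between measured compounds can be sized. Compound 4 `Cc1cc(C)nc(SCc2cc(=O)c3ccccc3o2)n1` differs from compound 1 by hydrogen in place of chloro on an aromatic carbon. Going by the values given here, with no measured step to lean on, the expected step from compound 1 to compound 4 is a step that the limit leaves unreadable from compound 1 to compound 4, nothing beyond the scatter in this assay. Compound 4 is therefore expected at about 35000 nM, between 12000 nM and 100000 nM, most likely again reported only as a limit.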

Compound 4, half-maximal inhibitory concentration: > 25000 nM
Compound 4 was reported as a limit; the forecaster's own chance of this, stated with the estimate: 80%; the middle value is on the limit's open side.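

Compound 1 and compound 4 are both reported only as limits in this assay, so the step between them cannot be read. The compounds shown leave open whether hydrogen in place of chloro changes cytotoxicity at all.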